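A few compounds are considered here, and "the series" means these few. Any claim that something is new, unique, unknown or untested is made for them only; others in the source may bear on it.

Of the compounds shown here, three have so far been measured in an assay for inhibition of cytochrome P450 1A1 (Homo sapiens), read by fluorescence, using microsomes, with a stated time of 10 min; a lower number here means a stronger inhibitor, a higher number a weaker inhibitor. Compound 1 `O=C(/C=C/c1cccc(Cl)c1)c1ccc[nH]1` gives 16000 nM, the highest of the three numbers. Compound 2 `COc1ccccc1/C=C/C(=O)c1ccc[nH]1` gives 900 nM, and compound 3 `COc1cccc(OC)c1/C=C/C(=O)c1ccc[nH]1` gives 10800 nM. The values of compound 1 and compound 3 lie within the usual scatter of each other, while the gap between compound 1 and compound 2 is beyond it. Within the data shown here, the only single-point step seen so far runs a 12-fold higher number from compound 2 to compound 3 (1.08 log units; beyond the scatter); it concerns a methoxy group on the six-membered ring, not a halogen.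

Compound 4 `O=C(/C=C/c1cccc(Br)c1)c1ccc[nH]1` differs from compound 1 by bromo in place of chloro on an aromatic carbon. Among the measured compounds shown here, no measured step bears on the exchange of one halogen for another, so the expectation rests on the structural change alone and on the value of compound 1 itself. The expected step is a 1.1-fold lower number from compound 1 to compound 4 (0.06 log units; within the scatter), which amounts to none beyond the scatter. The estimate for compound 4 in this assay is therefore 14000 nM, with a range from 5000 nM to 40000 nM.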

Compound 4, half-maximal inhibitory concentration: > 20000 nM
Compound 4 ended at the assay's limit; the forecaster's own chance of this, stated with the estimate: 10%; middle value at least 1.4-fold (0.15 log units) from the limit.
By their numbers in this assay, from the lowest: compound 2; then compounds 3 and 1 (each within the scatter of the next). At a limit, above all of these: compound 4.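

Unlike the earlier methoxy step, this step concerns one halogen replacing another on the six-membered ring, and bromo brings no gain in strength as an inhibitor: the change reads as an at least 1.2-fold higher number from compound 1 to compound 4 (0.09 log units; that floor lies within the scatter). In this assay compound 4 gives > 20000 nM, which is a limit of the assay and not a number. The floor of this step lies within the scatter, so chloro and bromo at this position may lie close together or far apart, and the reading stops at the limit: the limit of > 20000 nM in this assay, at which 1 of the 4 values shown sits.

From the compounds shown here alone, how far compound 4 truly lies from compound 1 stays open. Also open, going by these compounds, is what another group on this same aromatic carbon, such as fluoro, an amine or a carboxylic acid, would do to the number.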